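Notes: ethynyl in place of trifluoromethyl

The compounds below may be only part of what the source reports. "The series", "measured", "known", "first", "only" and "open" are said of these compounds alone.

Measured in a functional assay on MCF7 cells (Homo sapiens) for cytotoxicity, read by MTT assay, with a stated time of 24 h; on this read-out higher numbers stand for weaker inhibition and lower numbers for stronger inhibition:
- compound 1 `COc1cc2ncnc(Nc3cccc(C(F)(F)F)c3)c2cc1OCCCSc1nc2ccccc2s1`: 4050 nM
- compound 2 `CCCCc1nc(Cl)c(CO)n1CCCOc1cc2c(Nc3cccc(C(F)(F)F)c3)ncnc2cc1OC`: 8280 nM

Compound 2, at 8280 nM, holds the higher of the two numbers in this assay. The next compound, compound 3 `C#Cc1cccc(Nc2ncnc3cc(OC)c(OCCCn4c(CCCC)nc(Cl)c4CO)cc23)c1`, is not yet measured. It keeps the chain group of compound 2, and its change is ethynyl in place of trifluoromethyl on an aromatic carbon. For the measured compounds named here, the only measured step, a 2.0-fold higher number from compound 1 to compound 2 (0.31 log units; beyond the scatter), is modest and lies at the far end of the chain, not on this aromatic ring. Going by the values given here, no measured step covers the present exchange, so the data fix no direction. Among the compounds with values here, with that single modest step from compound 1 as the only guide, no step beyond the scatter is expected in this assay. The estimated step is a 1.2-fold lower number from compound 2 to compound 3 (0.07 log units; within the scatter). For compound 3 the expected value is 7000 nM, with an estimated range of 3000 nM to 16000 nM.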

Compound 3, half-maximal inhibitory concentration: 10000 nM
Beside the measured number, compound 3's estimate is 1.4-fold (0.15 log units) below it; measured number inside the range.
By their numbers in this assay, from the lowest: compound 1; then compounds 2 and 3 (each within the scatter of the next).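

In this assay, ethynyl in place of trifluoromethyl on this aromatic carbon gives a 1.2-fold higher number from compound 2 to compound 3 (0.08 log units; within the scatter). For the compounds shown here, this is the first reading at this position: with the chain group of compound 2 held constant, the 3-(trifluoromethyl)phenyl and 3-ethynylphenyl forms cannot be told apart on this read-out, so the exchange is tolerated here without a change beyond the scatter. No measurement at hand bears on why the two groups read alike.

Open, as far as these compounds go, is whether the same exchange also reads alike with the (1,3-benzothiazol-2-yl)sulfanyl chain end of compound 1. Also open, from the compounds shown here alone, is whether a nitrile, a chlorine atom or a plain hydrogen on this aromatic carbon would move the number beyond the scatter.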